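Extending the Hydroxyalkyl Side Chain of Compound 3

The source may hold more compounds than are shown below. What is called first, only, known or untested is meant among the compounds shown, and "the series" means these compounds.

Of the compounds shown here, three have been measured in an assay on HEK293 cells for displacement of a labelled ligand from NPC1-like intracellular cholesterol transporter 1 (Homo sapiens); on this read-out lower numbers stand for stronger inhibition and higher numbers for weaker inhibition. Compound 1 `CC(C)(C)OC(=O)NC1CCN(C(=O)CN2CN(c3ccccc3)C3(CCN(C(=O)c4ccc(C(C)(C)C)cc4)CC3)C2=O)CC1` gives 8300 nM, compound 2 `CC(C)(C)OC(=O)NCCCNC(=O)CN1CN(c2ccccc2)C2(CCN(C(=O)c3ccc(C4CCCCC4)cc3)CC2)C1=O` gives 6000 nM, and compound 3 `CC(C)(C)c1ccc(C(=O)N2CCC3(CC2)C(=O)N(CC(=O)NCCO)CN3c2ccccc2)cc1` gives 1000 nM. Compound 3 therefore stands lowest of the three numbers; the nearest, compound 2, lies beyond the scatter, and compound 1 lies further away still. Compound 4 `CC(C)(C)c1ccc(C(=O)N2CCC3(CC2)C(=O)N(CC(=O)NCCCCO)CN3c2ccccc2)cc1` keeps the core of compound 3 and differs from it in one place: 2-hydroxyethyl in place of hydroxy on a saturated chain carbon, two bonds along the chain from an amide-type nitrogen. The side chain ending in the hydroxy group is thereby lengthened, with nothing else altered. For the measured compounds named here, no measured pair shows this change, so neither its size nor its direction is known from the data. Because compound 3 gives 1000 nM and the change is confined to one small chain, a step no larger than the scatter, in either direction, is expected. Compound 4 is accordingly estimated at 1200 nM, with a range from 400 nM to 3600 nM. The expected step is a 1.2-fold higher number from compound 3 to compound 4 (0.08 log units; within the scatter).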

Compound 4, half-maximal inhibitory concentration: 19200 nM
Compound 4: middle estimate off by 16-fold (1.20 log units), on the low side; measured number outside the range, above it.
By their numbers in this assay, from the lowest: compound 3; then compounds 2 and 1 (each within the scatter of the next); then compound 4.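

In this assay, 2-hydroxyethyl in place of hydroxy on a saturated chain carbon, two bonds along the chain from an amide-type nitrogen, gives a 19-fold higher number from compound 3 to compound 4 (1.28 log units; beyond the scatter), a large step. The counts of hydrogen-bond donors and acceptors are the same on both sides of this change and neither group carries a net charge, so keeping the chain-end hydroxy does not by itself preserve the number once the chain is lengthened at this position. Nothing available here accounts for the size of the step.

The compounds shown leave open whether (3-hydroxypropyl)amino in place of (2-hydroxyethyl)amino would give a step of intermediate size or one as large. They also leave open how a shorter chain, or an amine or carboxylic acid at the end of the two-carbon chain, would read.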